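The source may report more compounds than this note shows. Statements on the series, on what has been measured and on what is new or still open speak of the compounds shown alone.

Measured in a functional assay on A549 cells (Homo sapiens) for cytotoxicity, read by MTT assay, with a stated time of 72 h; on this read-out higher numbers stand for weaker inhibition and lower numbers for stronger inhibition:
- compound 1 `CN(C)Cc1ccc2nc(NC(=O)N/N=C/c3cn(Cc4ccccc4Cl)c4ccccc34)sc2c1`: 1080 nM
- compound 2 `CC1CCN(Cc2ccc3nc(NC(=O)N/N=C/c4cn(Cc5ccccc5Cl)c5ccccc45)sc3c2)CC1`: 3330 nM
- compound 3 `CCN(CC)Cc1ccc2nc(NC(=O)N/N=C/c3cn(Cc4ccccc4Cl)c4ccccc34)sc2c1`: 1390 nM

Compound 1 stands at the low end of these numbers, though not apart from its nearest neighbour: a 1.3-fold higher number from compound 1 to compound 3 (0.11 log units; within the scatter). The furthest is a 3.1-fold higher number from compound 1 to compound 2 (0.49 log units; beyond the scatter), and the remaining step is a 2.4-fold lower number from compound 2 to compound 3 (0.38 log units; beyond the scatter).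

Compound 4 `CN(C)Cc1ccc2nc(NC(=O)N/N=C/c3cn(Cc4ccc(Cl)c(Cl)c4)c4ccccc34)sc2c1` differs from compound 1 thus: 3,4-dichlorophenyl in place of 2-chlorophenyl on a saturated chain carbon bound to an aromatic nitrogen. This is 3,4-dichlorophenyl in place of 2-chlorophenyl on a saturated chain carbon bound to an aromatic nitrogen. All three measured steps change a different place, so none gives a direction here; they show only modest movement elsewhere in the series. The expected step in this assay is a 1.1-fold lower number from compound 1 to compound 4 (0.03 log units; within the scatter), which means none beyond the scatter. The estimated value for compound 4 is 1000 nM, with an expected range of 350 nM to 3000 nM.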

Compound 4, half-maximal inhibitory concentration: 940 nM
Compound 4: middle estimate off by 1.1-fold (0.03 log units), on the high side, and the stated range covers the measured number.
By their numbers in this assay, from the lowest: compounds 4, 1 and 3 (each within the scatter of the next); then compound 2.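

This is the first change shown on the saturated chain carbon bound to an aromatic nitrogen, and in this assay 3,4-dichlorophenyl in place of 2-chlorophenyl gives a 1.1-fold lower number from compound 1 to compound 4 (0.06 log units; within the scatter). The read-out therefore does not separate 2-chlorobenzyl from 3,4-dichlorobenzyl, even with the added chlorine. No measured evidence bears on why the two groups read alike.

Still open, going by these compounds, is how an unsubstituted benzyl, a 4-methoxybenzyl or a longer phenethyl chain would read at this place. Also open, on these data alone, is whether 3,4-dichlorobenzyl reads the same alongside diethylamino or 4-methylpiperidin-1-yl.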